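Widening the Amine Ring on the Core of Compound 2

The source may report more compounds than this note shows. Statements on the series, on what has been measured and on what is new or still open speak of the compounds shown alone.

compound 1: `CCCCN(C)c1nc(C(F)(F)F)ccc1CNC(=O)C(C)c1ccc(NS(C)(=O)=O)c(F)c1` — 0.8 nM
compound 2: `CC(C(=O)NCc1ccc(C(F)(F)F)nc1N1CCCC1)c1ccc(NS(C)(=O)=O)c(F)c1` — 0.6 nM
compound 3: `C[C@H](C(=O)NCc1ccc(C(F)(F)F)nc1N1CC[C@@H](N(C)C)C1)c1ccc(NS(C)(=O)=O)c(F)c1` — 101 nM

Of the compounds shown here, three have been measured in a functional assay on CHO-K1 cells for antagonist activity at transient receptor potential cation channel subfamily V member 1 (Homo sapiens), read by FLIPR; on this read-out lower numbers stand for stronger inhibition and higher numbers for weaker inhibition. Compound 2 holds the lowest number of the three. Its nearest neighbour is compound 1, reached by a 1.3-fold lower number from compound 1 to compound 2 (0.12 log units; within the scatter), a step that lies within the scatter. Going by the values given here, its furthest neighbour is compound 3, whose number stands far higher, well beyond the scatter; no single-point step connects compound 2 and compound 3, so only the two values themselves speak here.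

Compound 4 is `CC(C(=O)NCc1ccc(C(F)(F)F)nc1N1CCCCCC1)c1ccc(NS(C)(=O)=O)c(F)c1`. It differs from compound 2 in one place: azepan-1-yl in place of pyrrolidin-1-yl on an aromatic carbon.

Among the compounds with values here, only one measured step bears on this change, a 1.3-fold lower number from compound 1 to compound 2 (0.12 log units; within the scatter), which exchanged an open-chain amine for the five-membered ring on the same aromatic carbon with no movement beyond the scatter. Within the data shown here, no measured step changes the size of that ring, so nothing in the data points to a large effect in this assay. Compound 4 is therefore expected to give 1.5 nM, between 0.4 nM and 6 nM. The expected step is a 2.5-fold higher number from compound 2 to compound 4 (0.40 log units; beyond the scatter), most likely within the scatter, with a slight lean toward a higher number.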

Compound 4, inhibition constant: 0.8 nM
Compound 4: middle estimate off by 1.9-fold (0.27 log units), on the high side; the measured number falls inside the stated range.
By their numbers in this assay, from the lowest: compounds 2, 1 and 4 (each within the scatter of the next); then compound 3.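

In this assay, the seven-membered azepan-1-yl ring takes the place of pyrrolidin-1-yl with a 1.3-fold higher number from compound 2 to compound 4 (0.12 log units; within the scatter), so this position now has a measured change in ring size, where the earlier step had only exchanged an open-chain amine for the five-membered ring. The second new step, no change at the digits printed from compound 1 to compound 4 (within the scatter), compares the seven-membered ring directly with butyl(methyl)amino, and all three groups on this aromatic carbon lie within the scatter of one another, so neither ring size nor the open-chain form separates them here. No measured evidence accounts for this result.

The compounds shown leave open whether the same holds for a ring with a second hetero atom, such as morpholin-4-yl. They also leave open how an azepan-1-yl ring carrying a carboxylic acid would read out in this assay.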